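The source may hold more compounds than are shown below. What is called first, only, known or untested is meant among the compounds shown, and "the series" means these compounds.

Series notes. Three compounds carry measured numbers in an assay on isolated protein for activation of cGMP-dependent protein kinase 1 (Homo sapiens), read by ADP-Glo, with stated times of 30 min and 2 h, in the presence of a further agent that is not named here; on this read-out lower numbers stand for an effect already at smaller amounts and higher numbers for an effect only at larger amounts of compound: compound 1 `Cc1cc(C(=O)O)ccc1C(C)N1CCC[C@H](O[C@H](CO)c2cc(Cl)cc(Cl)c2)[C@@H]1c1ccccc1` gives 18000 nM, compound 2 `Cc1cc(C(=O)O)ccc1CN1CCC[C@H](O[C@H](CO)c2ccnc(Cl)c2)[C@@H]1c1ccccc1` gives 50000 nM, and compound 3 `Cc1cc(C(=O)O)ccc1CN1CC[C@H](OC(CO)c2cc(Cl)cc(Cl)c2)[C@@H]1c1ccccc1` gives 133000 nM. Compound 2 holds the second highest of the three numbers; its nearest neighbour is compound 3, at a higher number, and compound 1 stands furthest, at a lower number, both gaps being beyond the usual scatter. The unmeasured compound 4 `Cc1cc(C(=O)O)ccc1CN1CCC[C@H](O[C@H](CO)c2cc(F)cc(F)c2)[C@@H]1c1ccccc1` departs from compound 2 in one place: 3,5-difluorophenyl in place of 2-chloropyridin-4-yl on a saturated chain carbon bound to an oxygen on a saturated carbon and a saturated chain carbon. Going by the values given here, no direct step of this kind exists among the measured compounds, so a step from compound 2 to compound 4 toward a slightly lower number is expected, near the edge of the scatter, as a 1.7-fold lower number from compound 2 to compound 4 (0.22 log units; within the scatter). For compound 4 the expected value in this assay is 30000 nM, within 10000 nM to 100000 nM.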

Compound 4, half-maximal effective concentration: 1500 nM
Compound 4: the middle estimate sits 20-fold (1.30 log units) above what was measured; measured number outside the range, below it.
By their numbers in this assay, from the lowest: compound 4; then compound 1; then compound 2; then compound 3.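

At the place on a saturated chain carbon bound to an oxygen on a saturated carbon and a saturated chain carbon, the aromatic group strongly governs the read-out in this assay: 3,5-difluorophenyl in place of 2-chloropyridin-4-yl gives a 33-fold lower number from compound 2 to compound 4 (1.52 log units; beyond the scatter). Going by these compounds alone, this is the first single-place change that can be read. No measurement shown bears on the cause of this step.

The exchange alters both ring atoms and halogens, and this one pair cannot separate the two. Open, from the compounds shown here alone, is how a phenyl carrying a single chlorine or a fluoropyridinyl group would read at this place.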